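Compound 3: from 2-fluorophenyl to 4-bromophenyl

The source may report more compounds than this note shows. Statements on the series, on what has been measured and on what is new or still open speak of the compounds shown alone.

compound 1 (`O=C(O)c1ccc(C(=O)/C(=C\c2ccc(Br)c([N+](=O)[O-])c2)SCc2ccc(Br)cc2)cc1`) measured at (1000 nM)
compound 2 (`O=C(O)c1ccc(C(=O)/C(=C\c2ccccc2F)SCc2ccc(Br)cc2)cc1`) measured at (10000 nM)
compound 3 (`O=C(O)c1ccc(C(=O)/C(=C\c2ccc(Br)cc2)SCc2ccc(Br)cc2)cc1`) not yet measured

In a functional assay on DU-145 cells (Homo sapiens) for inhibition, read by trypan blue exclusion, with a stated time of 96 h (a higher number here means a weaker inhibitor of growth, a lower number a stronger inhibitor of growth), compound 2 stands at (10000 nM) as the highest of the two numbers, with compound 1 nearest. The change to compound 3 (4-bromophenyl in place of 2-fluorophenyl on a double-bonded chain carbon bound to a double-bonded chain carbon) puts 4-bromophenyl in place of 2-fluorophenyl on a double-bonded chain carbon bound to a double-bonded chain carbon. Among the measured compounds shown here, one measured step bears on it (a 10-fold higher number from compound 1 to compound 2 (1.00 log units; beyond the scatter)) and lies beyond the scatter, with 2-fluorophenyl replacing 4-bromo-3-nitrophenyl at that place. The entering group keeps the bromo of the group in compound 1 but has no nitro, so only a partial return is expected, and one step is thin support. The expected change is (a 3.3-fold lower number from compound 2 to compound 3 (0.52 log units; beyond the scatter)) toward a lower number in this assay for this pair. For compound 3 the estimate is (3000 nM) with an expected range from (1000 nM) to (9000 nM) in this series.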

Compound 3, concentration for 50% growth inhibition: 1000 nM
For compound 3 the middle estimate is 3.0-fold (0.48 log units) above the measured one; measured number inside the range.
By their numbers in this assay, from the lowest: compounds 1 and 3 (each within the scatter of the next); then compound 2.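

In this assay, 4-bromophenyl in place of 2-fluorophenyl on a double-bonded chain carbon bound to a double-bonded chain carbon gives a 10-fold lower number from compound 2 to compound 3 (1.00 log units; beyond the scatter), so the whole of the earlier step of a 10-fold higher number from compound 1 to compound 2 (1.00 log units; beyond the scatter) is matched without any nitro on the entering group. With hydrogen in place of nitro on an aromatic carbon, the comparison reads no change at the digits printed from compound 1 to compound 3 (within the scatter), so the nitro of compound 1 makes no difference that can be read in this assay. Nothing measured here bears on the reason for either step.

The step to compound 3 removes the 2-fluoro and adds the 4-bromo at once, and the two changes cannot be told apart. A plain phenyl or a 4-fluorophenyl at this place would separate them, and an amine there would test a quite different kind of group.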